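Weakly active chalcone analogues and a sulfonyl replacement

A few compounds are considered here, and "the series" means these few. Any claim that something is new, unique, unknown or untested is made for them only; others in the source may bear on it.

The measured compounds and their values in a functional assay on DU-145 cells (Homo sapiens) for inhibition, read by trypan blue exclusion, with a stated time of 96 h; on this read-out lower numbers stand for stronger inhibition of growth and higher numbers for weaker inhibition of growth:
Compound 1, `CN(C)c1ccc(/C=C(/SCc2ccc(F)cc2)C(=O)c2ccc(Cl)cc2)cc1`: 50000 nM
Compound 2, `Cc1ccc(CS(=O)(=O)/C(=C/c2ccc(N(C)C)cc2)C(=O)c2ccc(Cl)cc2)cc1`: 50000 nM
Compound 3, `CN(C)c1ccc(/C=C(/SCc2ccc(Cl)cc2)C(=O)c2ccc(Cl)cc2)cc1`: > 100000 nM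

In this assay compound 1 gives 50000 nM and compound 2 gives 50000 nM, two values within the scatter of each other. Compound 3 reaches only a limit of the assay, > 100000 nM, so no number is known for it. Within the data shown here, the one step measured, an at least 2.0-fold higher number from compound 1 to compound 3 (0.30 log units; that floor lies within the scatter), consists of chloro in place of fluoro on an aromatic carbon, and its size rests on (the limit of > 100000 nM in this assay, at which 1 of the 3 values shown sits), so it is only a floor.

Compound 4, `CN(C)c1ccc(/C=C(\C(=O)c2ccc(Cl)cc2)S(=O)(=O)c2ccc(Br)cc2)cc1`, differs from compound 3 in one place: (4-bromophenyl)sulfonyl in place of (4-chlorobenzyl)sulfanyl on a double-bonded chain carbon bound to a carbonyl carbon and a double-bonded chain carbon. Among the measured compounds shown here, no measured step involves this change. Compound 2 carries a sulfonyl and sits in the same weak range as compound 1, which suggests little movement. Compound 4 is therefore expected to show a step of an at least 1.6-fold lower number from compound 3 to compound 4 (0.22 log units; that floor lies within the scatter) in this assay, not beyond the scatter. Compound 4 is estimated at 60000 nM, within the range 20000 nM to 150000 nM.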

Compound 4, concentration for 50% growth inhibition: > 100000 nM
Compound 4: only a limit was reported; the forecaster's own chance of this, stated with the estimate: 40%; at least 1.6-fold (0.22 log units) between middle value and limit.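

Compound 4 reaches only a limit in this assay, > 100000 nM, so placing (4-bromophenyl)sulfonyl on this double-bonded chain carbon brings no readable growth inhibition. Compared with the two compounds that have numbers, the result is an at least 2.0-fold higher number from compound 2 to compound 4 (0.30 log units; that floor lies within the scatter) and an at least 2.0-fold higher number from compound 1 to compound 4 (0.30 log units; that floor lies within the scatter), so neither floor shows a real loss beyond the scatter, and the sulfonyl of compound 2 and the one in compound 4 both stay in the weak range. The step between compound 3 and compound 4 cannot be read because both values are limits: the limit of > 100000 nM in this assay, at which 2 of the 4 values shown sit.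

The compounds shown leave open how far past the limit compound 3 and compound 4 really lie. They also leave open whether an amine or a carboxylic acid on this carbon, or a longer chain between the sulfonyl and its ring, would give measurable inhibition.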